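Propargyl in place of prenyl on the oxygen

The source may report more compounds than this note shows. Statements on the series, on what has been measured and on what is new or still open speak of the compounds shown alone.

- compound 1 `COc1ccc(/C=C/C(=O)c2ccc(OC)c3c2OC(C)(C)C=C3)cc1O`: 800 nM
- compound 2 `COc1ccc(/C=C/C(=O)c2ccc(OC)c3c2OC(C)(C)C=C3)cc1OCC=C(C)C`: > 10000 nM, a limit

Both values come from a functional assay on A-375 cells (Homo sapiens) for cytotoxicity, read by MTT assay; a lower number here means a stronger inhibitor, a higher number a weaker inhibitor. Compound 2 stands at the limit of > 10000 nM in this assay, at which 1 of the 2 values shown sits, so it has a limit and no number.

Compound 3 `C#CCOc1cc(/C=C/C(=O)c2ccc(OC)c3c2OC(C)(C)C=C3)ccc1OC` carries propargyl in place of the 3-methylbut-2-en-1-yl of compound 2 (ethynyl in place of 2-methylprop-1-en-1-yl on a saturated chain carbon bound to an oxygen on an aromatic ring). Going by the values given here, the one measured step that bears on this is an at least 12-fold higher number from compound 1 to compound 2 (1.09 log units; beyond the scatter), a large step that puts 3-methylbut-2-en-1-yl in place of hydrogen on the same oxygen. Compound 3 keeps a group on that oxygen, but a smaller one, so only a partial return towards compound 1 is expected, and part of the estimated range runs up to the limit. The expected step in this assay is an at least 2.5-fold lower number from compound 2 to compound 3 (0.39 log units; beyond the scatter), towards a lower number, with its size uncertain. For compound 3 the estimated value is 4000 nM, with an expected range of 1500 nM to 10000 nM.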

Compound 3, half-maximal inhibitory concentration: > 10000 nM
Compound 3: only a limit was reported (the forecaster's own chance of this, stated with the estimate: 35%); at least 2.5-fold (0.39 log units) between middle value and limit.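

Propargyl on the oxygen on an aromatic ring gives, in this assay, an at least 12-fold higher number from compound 1 to compound 3 (1.09 log units; beyond the scatter), so a second group on this oxygen, with ethynyl in place of 2-methylprop-1-en-1-yl, now stands against the hydrogen of compound 1. The value of compound 3, > 10000 nM, is a limit. The step between compound 2 and compound 3 cannot be read, since both compounds sit at the same limit: the limit of > 10000 nM in this assay, at which 2 of the 3 values shown sit.

As far as these compounds go, how far past the limit either compound lies stays open, so propargyl and 3-methylbut-2-en-1-yl cannot be ranked against each other. Also open, from the compounds shown here alone, is whether a methyl or a 2-aminoethyl group on this oxygen would give a value closer to that of compound 1, 800 nM.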